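A Methyl Added to Compound 1: Expected Tolerance

The source may report more compounds than this note shows. Statements on the series, on what has been measured and on what is new or still open speak of the compounds shown alone.

The measured compounds and their values in an ADME assay on Vero C1008 cells (Chlorocebus sabaeus) for cytotoxicity, read by luminescence and CellTiter-Glo, with a stated time of 24 h; a higher number here means that more compound is tolerated, a lower number that less compound is tolerated:
Compound 1, `O=C[C@H](C[C@@H]1CCNC1=O)NC(=O)[C@H](CC1CC1)NC(=O)OCc1ccccc1`: > 200000 nM
Compound 2, `O=C[C@H](C[C@@H]1CCNC1=O)NC(=O)[C@H](CC1CCCCC1)NC(=O)OCc1ccccc1`: > 200000 nM
Compound 3, `CC(C)C[C@H](NC(=O)OCc1cccc(F)c1)C(=O)N[C@H](C=O)C[C@@H]1CCNC1=O`: > 200000 nM

Each of these three values is a limit of this assay rather than a number. Compound 1 therefore has no measured position in this assay beyond that limit, and the two further values shown are limits as well. Among the compounds with values here, the one comparison between measured compounds that differ in a single place is a step that the two limits leave unreadable from compound 1 to compound 2, and it cannot be read because both ends sit at the limit, as the limit of > 200000 nM in this assay, at which 3 of the 3 values shown sit, records.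

Compound 4, `C[C@H](OC(=O)N[C@@H](CC1CC1)C(=O)N[C@H](C=O)C[C@@H]1CCNC1=O)c1ccccc1`, is not yet measured. It differs from compound 1 by methyl in place of hydrogen on a saturated chain carbon bound to an aromatic carbon and an oxygen next to a carbonyl group. Within the data shown here, no measured step involves a change of this kind, so there is nothing to set a size or direction for it; the only evidence is that all three measured compounds sit at the limit.

The step from compound 1 to compound 4 is therefore expected to be a number no higher from compound 1 to compound 4 (the limit leaves the size open), meaning no movement beyond the scatter, with compound 4 most likely reported as a limit again. For compound 4 the estimated value in this assay is 200000 nM, with a range from 100000 nM to 400000 nM.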

Compound 4, half-maximal cytotoxic concentration: > 200000 nM
Compound 4 gave a limit, no number; the forecaster's own chance of this, stated with the estimate: 85%; the middle value sits exactly at the limit.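

In this assay compound 4 gives > 200000 nM, which is a limit and not a number. The step between compound 1 and compound 4 therefore cannot be read, because both ends sit at that limit: the limit of > 200000 nM in this assay, at which 4 of the 4 values shown sit.

The compounds shown leave open how much of any of them is tolerated, and whether the added methyl changes that amount at all.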